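Chain extension at the aryl ether oxygen: exposure notes

The source may report more compounds than this note shows. Statements on the series, on what has been measured and on what is new or still open speak of the compounds shown alone.

Measured so far:
compound 1 `NCCOc1ccc([C@H]2CC[C@]3(CC2)OOC2(O3)C3CC4CC(C3)CC2C4)cc1` — 287 nM
compound 2 `N[C@H]1CC[C@@H](Oc2ccc([C@H]3CC[C@]4(CC3)OOC3(O4)C4CC5CC(C4)CC3C5)cc2)CC1` — 1170 nM

In an ADME assay on the whole organism (strain FVB) for pharmacokinetics, with Mus musculus as the target, read by LC-MS, at a dose of 30 mg/kg by the oral route (a lower number here means less compound in the circulation, a higher number more compound in the circulation at the dose given), compound 1 gives 287 nM, the lowest of the two numbers recorded. For the measured compounds named here, compound 2 gives 1170 nM, and the one measured step, a 4.1-fold higher number from compound 1 to compound 2 (0.61 log units; beyond the scatter), is the only change to the group on the ether oxygen seen so far. Compound 3 `NCCCCOc1ccc([C@H]2CC[C@]3(CC2)OOC2(O3)C3CC4CC(C3)CC2C4)cc1` differs from compound 1 by 2-aminoethyl in place of amino on a saturated chain carbon, two bonds along the chain from an oxygen on an aromatic ring. The measured step swaps the chain for a ring rather than lengthening it, so it bears on compound 3 only loosely; it shows that altering this group can move the maximal plasma concentration upward, but nothing here distinguishes a longer chain from a ring. A small rise, or no step beyond the scatter, is therefore expected, a 1.4-fold higher number from compound 1 to compound 3 (0.14 log units; within the scatter). Compound 3 is estimated at 400 nM, with a range of 150 nM to 1100 nM.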

Compound 3, maximal plasma concentration: 370 nM
Beside the measured number, compound 3's estimate is 1.1-fold (0.03 log units) above it; measured number inside the range.
By their numbers in this assay, from the lowest: compounds 1 and 3 (each within the scatter of the next); then compound 2.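

In this assay, extending the group on the aryl ether oxygen from 2-aminoethyl to 4-aminobutyl gives a step within the scatter (a 1.3-fold higher number from compound 1 to compound 3 (0.11 log units; within the scatter)), so this added chain length does not separate the two compounds. Replacing the 4-aminocyclohexyl group with 4-aminobutyl gives a step beyond the scatter (a 3.2-fold lower number from compound 2 to compound 3 (0.50 log units; beyond the scatter)), which shows that the chain does not reproduce the number seen with the ring and places the only clear difference among these three compounds at compound 2. No evidence on hand accounts for the gap between the ring and the chains.

Still open, from the compounds shown here alone, is whether a shorter ring amine, such as a 3-aminocyclobutyl or a 4-piperidinyl group, would keep the number of compound 2. Also open, going by these compounds, is how a dimethylamino group in place of the primary amine would read on either the chain or the ring.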